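Swapping the Aryl Group on a Fused Pyranone Core

The compounds below may be only part of what the source reports. "The series", "measured", "known", "first", "only" and "open" are said of these compounds alone.

Of the compounds shown here, two have been measured so far in a functional assay on KB cells (Homo sapiens) for antiproliferative activity, read by sulforhodamine B assay, with a stated time of 3 days; on this read-out lower numbers stand for an effect already at smaller amounts and higher numbers for an effect only at larger amounts of compound. Compound 1, with the structure `CCC1=C(O)c2c(oc(-c3ccc(F)cc3)cc2=O)C(CC)(CC)C1=O`, gives 33 uM in this assay. Compound 2, with the structure `CCC1=C(O)c2c(oc(-c3ccc(OC)c(C)c3C)cc2=O)C(CC)(CC)C1=O`, gives 5.43 uM in this assay. On these two numbers compound 1 stands at the higher end: its value is the highest of the two, and the gap to compound 2 lies beyond the usual scatter of repeated measurements, so compound 2 shows an effect at smaller amounts than compound 1 does.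

Compound 3, with the structure `CCC1=C(O)c2c(oc(-c3cc(C)cc(C)c3)cc2=O)C(CC)(CC)C1=O`, has not yet been measured in this assay. Relative to compound 1 the single change is 3,5-dimethylphenyl in place of 4-fluorophenyl on an aromatic carbon. The two measured compounds give only a loose footing for an expectation, yet the lower value of compound 2 with its methyl-bearing ring, 5.43 uM, suggests that a methyl-bearing ring in compound 3 may likewise move the number downward. The step from compound 1 to compound 3 is therefore expected to be a decrease of moderate size, a 3.3-fold lower number from compound 1 to compound 3 (0.52 log units; beyond the scatter). Compound 3 is accordingly estimated at 10 uM in this assay, with a plausible range from 3 uM to 40 uM.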

Compound 3, concentration for half-maximal effect: 45.5 uM
The estimate for compound 3 lay 4.6-fold (0.66 log units) below the measured number; measured number above the stated range.
By their numbers in this assay, from the lowest: compound 2; then compounds 1 and 3 (each within the scatter of the next).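

At this position, the aromatic carbon next to the ring oxygen, 3,5-dimethylphenyl in place of 4-fluorophenyl gives a 1.4-fold higher number from compound 1 to compound 3 (0.14 log units; within the scatter) in this assay, so the two compounds cannot be told apart on this read-out. Methyl groups on the aryl ring are therefore not tied on their own to a lower number at this position, and for this one exchange the loss of the fluorine and the gain of the two methyl groups leave the result within the scatter. Nothing measured here bears on why these two aryl groups read alike.

On these data alone, it remains open which feature of the aryl ring of compound 2, which gives 5.43 uM, goes with its value, as that ring carries a methoxy group as well as two methyl groups. As far as these compounds go, it is also open whether an amine or a carboxylic acid on the aryl ring, or a longer chain in place of the ethyl groups on the shared core, would move the number in this assay's read-out beyond the scatter.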